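The source may hold more compounds than are shown below. What is called first, only, known or untested is meant among the compounds shown, and "the series" means these compounds.

Of the compounds shown here, three sharing one core have been read in a toxicity assay on MT4 cells (Homo sapiens) for cytotoxicity, read by MTT assay; a lower number here means that less compound is tolerated, a higher number that more compound is tolerated. Compound 1 (`Cc1cc(-c2ccc(Cl)cc2)cc(C)c1Oc1cc(N)nc(Nc2ccc(C#N)cc2)n1`) gives 21500 nM, compound 2 (`Cc1ccc(-c2cc(C)c(Oc3cc(N)nc(Nc4ccc(C#N)cc4)n3)c(C)c2)cc1`) gives 10000 nM, and compound 3 (`COc1ccccc1-c1cc(C)c(Oc2cc(N)nc(Nc3ccc(C#N)cc3)n2)c(C)c1`) gives 21800 nM. Compound 3 thus lies within the scatter of compound 1, and both numbers stand above that of compound 2.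

Compound 4 (`Cc1cc(-c2ccccc2C#N)cc(C)c1Oc1cc(N)nc(Nc2ccc(C#N)cc2)n1`) has cyano in place of methoxy on an aromatic carbon, ortho to a large group: cyano in place of methoxy on an aromatic carbon. The same difference reads as 2-methoxyphenyl to 2-cyanophenyl. Among the measured compounds shown here, no measured step makes this exact exchange, so the evidence is indirect.

Three measured steps alter the same aryl group. The first, a 1.0-fold higher number from compound 1 to compound 3 (0.01 log units; within the scatter), stays within the scatter. The other two are only modest: a 2.2-fold lower number from compound 1 to compound 2 (0.33 log units; beyond the scatter) and a 2.2-fold higher number from compound 2 to compound 3 (0.34 log units; beyond the scatter). Across these three compounds, the changes have therefore moved the number little, and they give no firm direction for a nitrile.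

The expected outcome is no step beyond the scatter, and the estimate is a 1.4-fold lower number from compound 3 to compound 4 (0.13 log units; within the scatter). The middle is set slightly towards the span of the three measured values rather than on compound 3 alone. The expected value for compound 4 is 16000 nM, with an estimated range from 7000 nM to 35000 nM.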

Compound 4, half-maximal cytotoxic concentration: 25400 nM
Compound 4: middle estimate off by 1.6-fold (0.20 log units), on the low side; the measured number falls inside the stated range.
By their numbers in this assay, from the lowest: compound 2; then compounds 1, 3 and 4 (each within the scatter of the next).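

In this assay, the direct exchange of methoxy for cyano on this aromatic carbon, ortho to a large group, gives a 1.2-fold higher number from compound 3 to compound 4 (0.07 log units; within the scatter) and so stays within the usual scatter, which means that the nitrile is now shown to be tolerated here about as well as the methoxy group. The other two comparisons place the new compound in the same way: the 2-cyanophenyl group in place of 4-chlorophenyl gives a 1.2-fold higher number from compound 1 to compound 4 (0.07 log units; within the scatter) and stays within the scatter, whereas in place of 4-methylphenyl it gives a 2.5-fold higher number from compound 2 to compound 4 (0.40 log units; beyond the scatter) and remains a modest step, leaving compound 2 as the only one of the four that stands apart from the rest. Nothing in the material shown accounts for the separate position of the 4-methylphenyl compound or for the similar numbers of the other three.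

Going by these compounds, what an amine or a carboxylic acid would do in place of the cyano on this aromatic carbon remains open. So does the question of whether the number would stay in the same range with a longer chain there, since the four compounds shown cover only chloro, methyl, methoxy and cyano on this aryl group.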